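This account rests on a few compounds, and the source may have more. Where it says the series, first, only, none or still open, it means among the compounds named here.

Of the compounds shown here, three have been measured in an ADME assay on A549 cells (Homo sapiens) for cytotoxicity, read by resazurin assay, with a stated time of 48 h; a lower number here means that less compound is tolerated, a higher number that more compound is tolerated. Compound 1 `O=C(Nc1cc(F)cc(C(F)(F)F)c1)c1ccccc1O` gives 16300 nM, compound 2 `O=C(Nc1cc(F)cc(C(F)(F)F)c1)c1ccc(Cl)cc1O` gives 20600 nM, and compound 3 `O=C(NCc1ccc(Cl)cc1Cl)c1cc(Cl)ccc1O` gives 30900 nM. All three numbers lie within the scatter of one another, so no order among them can be read from these data.

Compounds 2 and 1 differ in a single place: hydrogen in place of chloro on an aromatic carbon. Across this change, this assay moves by a 1.3-fold lower number from compound 2 to compound 1 (0.10 log units; within the scatter), a step that does not rise above the noise of the measurement.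

Compound 4 `O=C(NCc1ccc(Cl)cc1)c1cc(Cl)ccc1O` has not yet been measured in this assay. It is related to compound 3 by the same kind of change: hydrogen in place of chloro on an aromatic carbon. The surroundings of the place are not identical, however. In the pair of compound 2 and compound 1 the carbon that loses its chloro is meta to a hydroxy group and para to a large group, whereas in compound 3 it is ortho to a large group and meta to a chloro group. The cores of compound 2 and compound 3 also differ, and that difference is not broken down here.

Going by the values given here, because the one earlier step of this kind, a 1.3-fold lower number from compound 2 to compound 1 (0.10 log units; within the scatter), stayed within the scatter, the change from compound 3 is expected to do little, with an expected step of a 1.1-fold lower number from compound 3 to compound 4 (0.06 log units; within the scatter) in this assay. Compound 4 is therefore estimated to give about 27000 nM, with a likely range from 13000 nM to 56000 nM.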

Compound 4, half-maximal cytotoxic concentration: 27100 nM
For compound 4 the middle estimate is 1.0-fold (0.00 log units) below the measured one, and the stated range covers the measured number.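

In this assay, putting hydrogen in place of the chloro on the aromatic carbon gives a 1.1-fold lower number from compound 3 to compound 4 (0.06 log units; within the scatter), so on this second core the change again leaves the number within the noise of the measurement. Setting the two cases side by side shows that the change behaves alike on both cores, with no detectable difference between them: the same change on two cores in this assay, a 1.3-fold lower number (0.10 log units; within the scatter) from compound 2 to compound 1 and a 1.1-fold lower number (0.06 log units; within the scatter) from compound 3 to compound 4, 1.1-fold (0.04 log units) apart, within the scatter of two such steps This supports a modest statement, that removing this chloro did little in these two pairs, even though the carbon sits in different surroundings in each, but it does not show a general rule for the series, since two small steps cannot reveal whether a core or a position influences the size of the step, and they give no reason why the step is small.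

The compounds shown leave open whether a different group at this same place, such as an amine, a carboxylic acid or a longer chain, would move the number beyond the scatter. They also leave open what would happen if the hydroxy group or the amide that all four compounds share were replaced.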